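Dipropylamino for cyclohexylamino: expectation for a fourth analogue

The compounds below may be only part of what the source reports. "The series", "measured", "known", "first", "only" and "open" are said of these compounds alone.

Compound 1 `O=C1C=C(NC2CCCCC2)C(=O)c2c1nc1n2[C@H]2OC[C@@H](O)[C@H]2OC1` and compound 3 `O=C1C(NC2CCCCC2)=CC(=O)c2c1nc1n2[C@H]2OC[C@@H](O)[C@H]2OC1` are built from the same atoms joined differently; the difference between the two cores is not broken down here. In a functional assay on HeLa cells (Homo sapiens) for inhibition, read by sulforhodamine B assay (a higher number here means a weaker inhibitor, a lower number a stronger inhibitor), compound 1 gives only a limit, > 16000 nM. Compound 3 in this assay likewise gives only a limit, > 16000 nM. Compound 2 `CCCN(CCC)C1=CC(=O)c2nc3n(c2C1=O)[C@H]1OC[C@@H](O)[C@H]1OC3` carries the change dipropylamino in place of cyclohexylamino on a double-bonded ring carbon on the core of compound 1. In this assay compound 2 also gives only a limit, > 16000 nM. The step that the two limits leave unreadable from compound 1 to compound 2 is thus unreadable, every value sitting at the limit of > 16000 nM in this assay, at which 3 of the 3 values shown sit. Compound 4 `CCCN(CCC)C1=CC(=O)c2c(nc3n2[C@H]2OC[C@@H](O)[C@H]2OC3)C1=O` carries the same change on the core of compound 3, (dipropylamino in place of cyclohexylamino on a double-bonded ring carbon). Given that compound 1 and compound 2 both sit at the limit of > 16000 nM in this assay, at which 3 of the 3 values shown sit, the step that the limit leaves unreadable from compound 3 to compound 4 is expected to be small. Compound 4 is expected most likely to read as a limit again, with an estimate of 30000 nM, between 10000 nM and 100000 nM.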

Compound 4, half-maximal inhibitory concentration: > 16000 nM
Compound 4 was reported as a limit (the forecaster's own chance of this, stated with the estimate: 85%); the middle value is on the limit's open side.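

In this assay, within the data shown here, compound 3 and compound 4 both stand only as limits, and no step between them can be read. The compounds shown leave open whether cyclohexylamino and dipropylamino differ at all in inhibition on either core.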